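Trimming a chlorine from a dichlorophenyl ketone

The source may report more compounds than this note shows. Statements on the series, on what has been measured and on what is new or still open speak of the compounds shown alone.

Of the compounds shown here, three have been measured in an assay on isolated protein for binding affinity to 5-hydroxytryptamine receptor 1D (Homo sapiens); on this read-out lower numbers stand for stronger inhibition and higher numbers for weaker inhibition. Compound 1 `CCCN1[C@H](C)CN(c2cc3c(cc2OC)CCN3C(=O)c2ccc(-c3cccc(C)n3)c3ccccc23)C[C@@H]1C` gives 158 nM. Compound 2 `COc1cc2c(cc1N1C[C@@H](C)N(C)[C@@H](C)C1)N(C(=O)Nc1cccc(Cl)c1Cl)CC2` gives 79.4 nM. Compound 3 `COc1cc2c(cc1N1C[C@@H](C)N(C)[C@@H](C)C1)N(C(=O)c1cccc(Cl)c1Cl)CC2` gives 251 nM. Compound 3 thus carries the highest of the three numbers, though its gap to compound 1 lies within the usual scatter; only its gap to compound 2, which is a 3.2-fold higher number from compound 2 to compound 3 (0.50 log units; beyond the scatter), goes beyond it.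

Compound 4 `COc1cc2c(cc1N1C[C@@H](C)N(C)[C@@H](C)C1)N(C(=O)c1cccc(Cl)c1)CC2` differs from compound 3 in one place: hydrogen in place of chloro on an aromatic carbon. For the measured compounds named here, no measured step concerns this kind of change; the single step in hand swaps an amino-bearing carbonyl for a plain carbonyl and runs a 3.2-fold higher number from compound 2 to compound 3 (0.50 log units; beyond the scatter), so it gives no direct guide. Going by the values given here, with only one atom removed and no measured precedent, compound 4 is expected to come out close to compound 3, the estimated step being a 1.3-fold higher number from compound 3 to compound 4 (0.11 log units; within the scatter), not beyond the scatter. Compound 4 is therefore estimated at 320 nM, with a range from 130 nM to 800 nM.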

Compound 4, inhibition constant: 251 nM
Compound 4: the middle estimate sits 1.3-fold (0.11 log units) above what was measured; low and high end bracket the measured number.
By their numbers in this assay, from the lowest: compounds 2, 1, 3 and 4 (each within the scatter of the next, the first and the last beyond it).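

In this assay, replacing the chloro group that sits ortho to a large group with hydrogen turns 2,3-dichlorophenyl into 3-chlorophenyl and gives no change at the digits printed from compound 3 to compound 4 (within the scatter), so this chlorine makes no readable difference to the number here. The distance to the compound with the (2,3-dichlorophenyl)amino group also holds, at a 3.2-fold higher number from compound 2 to compound 4 (0.50 log units; beyond the scatter), the same size as a 3.2-fold higher number from compound 2 to compound 3 (0.50 log units; beyond the scatter). No supporting data are available to explain why the number stays put.

On these data alone, it remains open whether the chloro group left on compound 4 matters in its own right, and what a fluoro or an amino group would do at the position now carrying hydrogen. Also open, as far as these compounds go, is whether the same swap would leave the number unchanged on compound 2.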